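Predicting a hydroxyphenyl analogue of a triazole-linked butenolide

A few compounds are considered here, and "the series" means these few. Any claim that something is new, unique, unknown or untested is made for them only; others in the source may bear on it.

Measured compounds:
compound 1 `O=C1O[C@H]([C@@H](O)Cn2cc(-c3ccc(Br)cc3)nn2)C(OCc2ccccc2)=C1OCc1ccccc1` — 3910 nM
compound 2 `O=C1O/C(=C\Cn2cc(-c3cc(F)cc(F)c3)nn2)C(OCc2ccccc2)=C1OCc1ccccc1` — 17700 nM
compound 3 `CC(C)(C)c1cn(C[C@H](O)[C@H]2OC(=O)C(OCc3ccccc3)=C2OCc2ccccc2)nn1` — 18300 nM

In a functional assay on HeLa cells (Homo sapiens) for antiproliferative activity, read by MTT assay, with a stated time of 72 h (on this read-out higher numbers stand for weaker inhibition and lower numbers for stronger inhibition), compound 2 gives 17700 nM, a higher number than compound 1 and essentially the same as compound 3. Compound 4 `O=C1O/C(=C\Cn2cc(-c3cccc(O)c3)nn2)C(OCc2ccccc2)=C1OCc1ccccc1` differs from compound 2 by one change: 3-hydroxyphenyl in place of 3,5-difluorophenyl on an aromatic carbon. Going by the values given here, the only measured step that alters the group on the triazole ring is a 4.7-fold higher number from compound 1 to compound 3 (0.67 log units; beyond the scatter), but it swaps an aryl group for an alkyl group on a different core, so it bears only loosely here. Among the compounds with values here, with no closer precedent, the step from compound 2 to compound 4 is expected to stay within the scatter, a 1.2-fold lower number from compound 2 to compound 4 (0.07 log units; within the scatter). Compound 4 is therefore estimated at 15000 nM, with a range of 5000 nM to 45000 nM.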

Compound 4, half-maximal inhibitory concentration: 74800 nM
Compound 4: the middle estimate sits 5.0-fold (0.70 log units) below what was measured; the whole stated range lies below it.
By their numbers in this assay, from the lowest: compound 1; then compounds 2 and 3 (each within the scatter of the next); then compound 4.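

In this assay, this carbon of the five-membered aromatic ring is sensitive even when the aryl ring stays: swapping 3,5-difluorophenyl for 3-hydroxyphenyl gives a 4.2-fold higher number from compound 2 to compound 4 (0.63 log units; beyond the scatter), a step beyond the scatter. The earlier step on the core of compound 1 replaced an aryl group with tert-butyl, so it could not show that changing only the groups on the aryl ring matters. Nothing available explains this shift.

Going by these compounds, the hydroxyl enters and both fluorines leave in one step, so their separate contributions remain open. On these data alone, how a methoxy group or an amine in place of the hydroxyl would read also remains open.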